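The source may hold more compounds than are shown below. What is called first, only, known or untested is meant among the compounds shown, and "the series" means these compounds.

Measured in a functional assay on a cell-free system (plasma, Homo sapiens), with a stated time of 3 min; a lower number here means a stronger inhibitor, a higher number a weaker inhibitor:
compound 1, `CC(C)(C)[C@@H](O)C(=O)N1[C@@H]2C[C@@H]2C[C@H]1C(=O)NCc1cc(Cl)ccc1-n1cnnn1`: 1100 nM
compound 2, `O=C(NCc1cc(Cl)ccc1-n1cnnn1)[C@@H]1C[C@@H]2C[C@@H]2N1C(=O)[C@H](O)Cc1ccccn1`: 1000 nM

Compound 2 and compound 1 give numbers within the scatter of each other, so neither stands apart in this assay. Among the measured compounds shown here, no step between measured compounds that differ in one place is available. Compound 3, `COC(C)(C)[C@@H](O)C(=O)N1[C@H](C(=O)NCc2cc(Cl)ccc2-n2cnnn2)C[C@@H]2C[C@@H]21`, differs from compound 2 by 1-methoxy-1-methylethyl in place of (pyridin-2-yl)methyl on a saturated chain carbon bound to a carbonyl carbon and an oxygen on a saturated carbon. Nothing measured here bears on this change, so no step beyond the scatter is expected in either direction in this assay. Compound 3 is estimated at 900 nM (range 400 nM to 2000 nM). The expected step is a 1.1-fold lower number from compound 2 to compound 3 (0.05 log units; within the scatter).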

Compound 3, half-maximal inhibitory concentration: 1000 nM
Beside the measured number, compound 3's estimate is 1.1-fold (0.05 log units) below it; measured number inside the range.
By their numbers in this assay, from the lowest: compounds 2, 3 and 1 (each within the scatter of the next).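

In this assay, replacing (pyridin-2-yl)methyl with 1-methoxy-1-methylethyl on this saturated chain carbon gives no change at the digits printed from compound 2 to compound 3 (within the scatter). The six-membered aromatic ring can therefore leave this position without a step beyond the scatter, and an acyclic group carrying an oxygen can take its place. No supporting measurement is available to account for this result.

As far as these compounds go, whether an amine or a carboxylic acid at this position would give a step beyond the scatter remains open. So does the effect of a longer chain.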